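The compounds below may be only part of what the source reports. "The series", "measured", "known", "first", "only" and "open" are said of these compounds alone.

The measured compounds:

Compound 1, `COc1ccc(/C=C/C(=O)OCC(=O)Nc2ccccc2)cc1OC`, in a functional assay on BEL-7404 cells (Homo sapiens) for cytotoxicity, read by MTT assay, with a stated time of 72 h (a higher number here means a weaker inhibitor, a lower number a stronger inhibitor), gives > 200000 nM, which is a limit of the assay rather than a number.

Compound 2, `COCOc1cc(/C=C/C(=O)OCC(=O)Nc2nccs2)ccc1OCc1ccccc1`, in this assay gives 130000 nM.

Among the compounds with values here, compound 2 therefore stands on the only numerical value in this assay; the other value shown is the limit described by the limit of > 200000 nM in this assay, at which 1 of the 2 values shown sits. Within the data shown here, both compounds sit at the weak end of what this assay can report, so there is no measured step between them to draw on.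

Compound 3, `COCOc1cc(/C=C/C(=O)OCC(=O)Nc2ccc(OC)cc2)ccc1OCc1ccccc1`, has not yet been measured in this assay. It differs from compound 2 in a single place: 4-methoxyphenyl in place of 1,3-thiazol-2-yl on an amide-type nitrogen. The ester and the core of compound 2 are kept unchanged.

Among the measured compounds shown here, with no measured step of this kind available, the expectation rests on the values of compound 2 and compound 1 alone, both of which lie very high in this assay. The step of a 1.2-fold higher number from compound 2 to compound 3 (0.06 log units; within the scatter) is expected to be small, with no direction beyond the usual scatter. Compound 3 is thus estimated to give about 150000 nM, with a range from 60000 nM to 400000 nM, and a real chance that this assay reports only a limit for it.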

Compound 3, half-maximal inhibitory concentration: 133000 nM
The estimate for compound 3 lay 1.1-fold (0.05 log units) above the measured number; low and high end bracket the measured number.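

The exchange of 1,3-thiazol-2-yl for 4-methoxyphenyl on the amide-type nitrogen appears in this assay as a 1.0-fold higher number from compound 2 to compound 3 (0.01 log units; within the scatter). Within the data shown here, this is the first measured step, and it shows that on this nitrogen a five-membered aromatic ring with two hetero atoms and a six-membered aromatic ring of carbon only cannot be told apart by this read-out, with the rest of compound 2 kept unchanged. Compound 1 remains a limit of the assay, not a number, and so adds no second step to set beside this one: the limit of > 200000 nM in this assay, at which 1 of the 3 values shown sits.

From the compounds shown here alone, it remains open whether any other group on the amide-type nitrogen, such as a 4-aminophenyl group, a 4-carboxyphenyl group or a longer alkyl chain, would give a step beyond the scatter in this assay. The compounds shown also leave open whether changes elsewhere would matter more than this one, for example an amide in place of the ester or a free hydroxyl group in place of the benzyl ether.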